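Two hydroxyls in place of chlorine and one hydroxyl

The source may report more compounds than this note shows. Statements on the series, on what has been measured and on what is new or still open speak of the compounds shown alone.

Of the compounds shown here, three sharing one core have been measured in a functional assay on MCF7 cells (Homo sapiens) for cytotoxicity, read by MTT assay, with a stated time of 48 h; on this read-out lower numbers stand for stronger inhibition and higher numbers for weaker inhibition. Compound 1 `O=C(CSc1nnc(-c2ccncc2)o1)N/N=C/c1ccc(Br)cc1` gives 19100 nM, compound 2 `O=C(CSc1nnc(-c2ccncc2)o1)N/N=C/c1ccccc1[N+](=O)[O-]` gives 35600 nM, and compound 3 `O=C(CSc1nnc(-c2ccncc2)o1)N/N=C/c1cc(Cl)ccc1O` gives 5830 nM, the lowest number of the three: it lies a 3.3-fold lower number from compound 1 to compound 3 (0.52 log units; beyond the scatter) and a 6.1-fold lower number from compound 2 to compound 3 (0.79 log units; beyond the scatter), both beyond the scatter, while the gap a 1.9-fold higher number from compound 1 to compound 2 (0.27 log units; within the scatter) is within it. Compound 4 `O=C(CSc1nnc(-c2ccncc2)o1)N/N=C/c1ccc(O)c(O)c1` keeps this core and differs from compound 3 only in the aryl group: 3,4-dihydroxyphenyl in place of 5-chloro-2-hydroxyphenyl on a carbon with a double bond to nitrogen. Going by the values given here, the steps that bear on this change are the two aryl swaps leading to compound 3, each of modest size, and no aryl change seen here moved the number further than that. Compound 4 is therefore expected to stay close to compound 3, with an expected step of a 1.2-fold lower number from compound 3 to compound 4 (0.07 log units; within the scatter), within the scatter. The estimate for compound 4 is 5000 nM, with a range from 1500 nM to 18000 nM.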

Compound 4, half-maximal inhibitory concentration: 910 nM
Compound 4: the middle estimate sits 5.5-fold (0.74 log units) above what was measured, outside the stated range (below it).
By their numbers in this assay, from the lowest: compound 4; then compound 3; then compounds 1 and 2 (each within the scatter of the next).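

On the carbon with a double bond to nitrogen, 3,4-dihydroxyphenyl takes this assay well past the earlier best, with a 6.4-fold lower number from compound 3 to compound 4 (0.81 log units; beyond the scatter) and with still larger gaps, a 21-fold lower number from compound 1 to compound 4 (1.32 log units; beyond the scatter) and a 39-fold lower number from compound 2 to compound 4 (1.59 log units; beyond the scatter) in the same direction. This aryl position can therefore move the number much further than the earlier swaps suggested, and compound 4 now has the lowest number of the four. No evidence at hand speaks to why this change has such an effect. On these data alone, the step swaps the whole aryl group, so the share of each hydroxyl and of the lost chlorine stays open. As far as these compounds go, whether methoxy or amino groups in place of these hydroxyls would keep the low number also remains open.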